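The source may hold more compounds than are shown below. What is called first, only, known or untested is meant among the compounds shown, and "the series" means these compounds.

Of the compounds shown here, two sharing one core have been measured so far in a functional assay on V79 cells (Cricetulus griseus) for cytotoxicity, read by colony formation; a higher number here means a weaker inhibitor, a lower number a stronger inhibitor. Compound 1 (`Nc1c(F)c(N2CCC(N)C2)cc2c1c(=O)c(C(=O)O)cn2C1CC1`), which carries an amino group, gives 54 ug/mL. Compound 2 (`Cc1c(F)c(N2CCC(N)C2)cc2c1c(=O)c(C(=O)O)cn2C1CC1`), which has a methyl group in its place, gives 14 ug/mL, the lower of the two numbers. Among the compounds with values here, that swap is the only measured step, a 3.9-fold lower number from compound 1 to compound 2 (0.59 log units; beyond the scatter), and it is a modest one that lies beyond the scatter.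

Compound 3 (`Cc1c(F)c(N2CCC(N)C2)c(C(F)(F)F)c2c1c(=O)c(C(=O)O)cn2C1CC1`) keeps everything in compound 2 and makes one change: trifluoromethyl in place of hydrogen on an aromatic carbon, ortho to a 3-aminopyrrolidin-1-yl group and para to a methyl group (trifluoromethyl in place of hydrogen on an aromatic carbon).

Within the data shown here, no measured compound shows what happens when this carbon is altered, so the step of a 3.9-fold lower number from compound 1 to compound 2 (0.59 log units; beyond the scatter) offers only a rough guide to how far one change can move the number on this core. Neither its size nor its direction carries over directly, so no clear move in either direction is expected. The expected step is a 1.2-fold lower number from compound 2 to compound 3 (0.07 log units; within the scatter), which stays within the scatter. For compound 3 the estimated value is 12 ug/mL, with an expected range of 4 ug/mL to 40 ug/mL.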

Compound 3, half-maximal inhibitory concentration: 290 ug/mL
Compound 3: the middle estimate sits 24-fold (1.38 log units) below what was measured, and the stated range ends below it.
By their numbers in this assay, from the lowest: compound 2; then compound 1; then compound 3.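

In this assay, placing trifluoromethyl on the aromatic carbon ortho to a 3-aminopyrrolidin-1-yl group and para to a methyl group gives a 21-fold higher number from compound 2 to compound 3 (1.32 log units; beyond the scatter), a large step towards a weaker inhibitor. Within the data shown here, this carbon had not been altered in the earlier compounds, and the result shows that it is not a neutral place on the shared core, since this single replacement of hydrogen moves the number further than the earlier swap of amino for methyl, which gave a 3.9-fold lower number from compound 1 to compound 2 (0.59 log units; beyond the scatter). No available measurement gives a reason for this rise.

With trifluoromethyl as the only replacement shown at this carbon, it remains open whether the rise belongs to that particular group or would follow other replacements of the hydrogen, such as a chloro, methoxy or nitrile group. Going by these compounds, it is also open whether trifluoromethyl would produce a step of similar size with an amino group in place of the methyl group, the one other variation seen on this core.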